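A few compounds are considered here, and "the series" means these few. Any claim that something is new, unique, unknown or untested is made for them only; others in the source may bear on it.

Measured in an ADME assay on cells (Macrophage, Mus musculus) for cytotoxicity, read by resazurin assay, with a stated time of 3 days; a higher number here means a weaker inhibitor, a lower number a stronger inhibitor:
- compound 1 `O=C(Nc1cc(C(F)(F)F)ccc1Cl)c1cc(Cl)ccc1O`: 3500 nM
- compound 2 `O=C(Nc1cc(F)cc(F)c1)c1cc(Cl)ccc1O`: 6100 nM
- compound 3 `O=C(Nc1cc(C(F)(F)F)ccc1Cl)c1cc(F)ccc1O`: 6100 nM

Compound 3 is compound 1 with fluoro in place of chloro on an aromatic carbon. That single change gave a 1.7-fold higher number from compound 1 to compound 3 (0.24 log units; within the scatter), so the two are not separated by more than the usual repeat scatter. Compound 1 and compound 2 differ in more than one place; the difference between the two cores is not broken down here. Compound 2 and compound 3 stand level at the digits recorded, and their gap to compound 1 is likewise within the scatter, so no order among the three is claimed.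

Not yet measured: compound 4 `O=C(Nc1cc(F)cc(F)c1)c1cc(F)ccc1O`. It is compound 2 with fluoro in place of chloro on an aromatic carbon. Going by the values given here, this is the same change as that taken from compound 1 to compound 3, at the same place; among the compounds here it occurs twice in all, and only the one instance has a number behind it.

For compound 4 the expected step is a 1.5-fold higher number from compound 2 to compound 4 (0.17 log units; within the scatter), placed beside the measured 1.7-fold higher number from compound 1 to compound 3 (0.24 log units; within the scatter). The expectation rests on that one earlier step, which stayed within the scatter, and on compound 2 giving 6100 nM as the starting point; with a single precedent the range is kept wide. Compound 4 is therefore estimated at 9000 nM, expected between 4000 nM and 20000 nM.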

Compound 4, half-maximal inhibitory concentration: 9600 nM
The estimate for compound 4 lay 1.1-fold (0.03 log units) below the measured number; measured number inside the range.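

In this assay, fluoro in place of chloro on an aromatic carbon, para to a hydroxy group, gives a 1.6-fold higher number from compound 2 to compound 4 (0.20 log units; within the scatter). Set beside the step on the core of compound 1, the result on the core of compound 2 agrees with it, and the two instances cannot be told apart: the same change on two cores in this assay, a 1.7-fold higher number (0.24 log units; within the scatter) from compound 1 to compound 3 and a 1.6-fold higher number (0.20 log units; within the scatter) from compound 2 to compound 4, 1.1-fold (0.04 log units) apart, within the scatter of two such steps. The change therefore carries across these two cores without a detectable difference, but each step stays within the scatter, so the pair does not establish that fluoro and chloro at this place truly separate the compounds, and it gives no cause and no basis for extending the reading to cores outside these two.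

The compounds shown leave open whether any group at this aromatic carbon would move the number beyond the scatter, since only chloro and fluoro appear there, and an amine, a carboxylic acid, a nitrile or a longer chain such as propyl could give a different reading. They also leave open how the hydroxy group and the amide linking the two aromatic rings contribute, as both stay the same throughout the four compounds, so replacing the hydroxy group with a methoxy group remains an untested question in this series.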